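A few compounds are considered here, and "the series" means these few. Any claim that something is new, unique, unknown or untested is made for them only; others in the source may bear on it.

In a functional assay on MGC-803 cells (Homo sapiens) for antiproliferative activity, read by MTT assay, with a stated time of 48 h (a higher number here means a weaker inhibitor, a lower number a stronger inhibitor), compound 1 (`COc1ccc(CN(C(=O)CCSc2nc3ccccc3o2)c2cc(OC)c(OC)c(OC)c2)cc1`) reads 640 nM and compound 2 (`COc1ccc(CN(C(=O)CCCSc2nc3ccccc3o2)c2cc(OC)c(OC)c(OC)c2)cc1`) reads 1290 nM. Compound 3 (`COc1ccc(CN(C(=O)CSc2nnnn2C)c2cc(OC)c(OC)c(OC)c2)cc1`) reads 2490 nM. Its two measured steps are a 3.9-fold higher number from compound 1 to compound 3 (0.59 log units; beyond the scatter), which lies beyond the scatter, and a 1.9-fold higher number from compound 2 to compound 3 (0.29 log units; within the scatter), which lies within it. Compound 4 (`COc1ccc(CN(C(=O)CSc2nncs2)c2cc(OC)c(OC)c(OC)c2)cc1`) differs from compound 3 on a sulfur: 1,3,4-thiadiazol-2-yl in place of 1-methyl-1H-tetrazol-5-yl on a sulfur. For the measured compounds named here, no measured step makes this exchange alone. The two steps into compound 3 change the group on the sulfur and the chain together, while a 2.0-fold higher number from compound 1 to compound 2 (0.30 log units; within the scatter) changes the chain only. All three are modest at most, so no change beyond the scatter is expected in this assay. The expected step is a 1.2-fold lower number from compound 3 to compound 4 (0.10 log units; within the scatter). Compound 4 is estimated at 2000 nM, with an expected range of 800 nM to 5000 nM.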

Compound 4, half-maximal inhibitory concentration: 1150 nM
The estimate for compound 4 lay 1.7-fold (0.24 log units) above the measured number; low and high end bracket the measured number.
By their numbers in this assay, from the lowest: compounds 1, 4, 2 and 3 (each within the scatter of the next, the first and the last beyond it).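

In this assay, for the compounds shown here, the exchange on the sulfur, taken alone, gives a 2.2-fold lower number from compound 3 to compound 4 (0.34 log units; beyond the scatter) and so is the first reading of this position with the chain held fixed. Where the group on the sulfur and the chain change together, a 1.1-fold lower number from compound 2 to compound 4 (0.05 log units; within the scatter) and a 1.8-fold higher number from compound 1 to compound 4 (0.25 log units; within the scatter) leave compound 4 level with both 1,3-benzoxazol-2-yl compounds. Nothing measured here accounts for the step on the sulfur.

Still open, going by these compounds, is how 1,3,4-thiadiazol-2-yl reads on the chains of compound 1 and compound 2, and how 1,3-benzoxazol-2-yl reads on the chain of compound 4. A phenyl or pyridine ring on the sulfur also remains to be read.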